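A Larger Ring on a Compound at the Assay Limit

The source may hold more compounds than are shown below. What is called first, only, known or untested is meant among the compounds shown, and "the series" means these compounds.

Compound 1 `CC1=CC[C@@]2([C@H](O)C1)[C@@H](C(=O)O)CC[C@H]2C(C)C`: > 500000 nM
Compound 2 `CC(=O)O[C@@H]1C[C@@](C)(O)CC[C@]12[C@@H](C(=O)O)CC[C@H]2C(C)C`: > 500000 nM
Compound 3 `CC1=CC[C@@]2([C@H](O)C1)[C@@H](C(=O)O)CC[C@H]2C1CCCCC1`: not yet measured

The test here is an ADME assay on 3T3-L1 cells (Mus musculus) for cytotoxicity, read by luminescence and CellTiter-Glo, with a stated time of 72 h; on this read-out lower numbers stand for an effect already at smaller amounts and higher numbers for an effect only at larger amounts of compound. In this assay, compound 1 gives > 500000 nM. This value is a limit of the assay and not a number. Compound 2 gives > 500000 nM, which is also a limit. The whole record so far is the limit of > 500000 nM in this assay, at which 2 of the 2 values shown sit, so compound 1 has no exact position on the scale.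

Compound 3 keeps the core of compound 1 but carries cyclohexyl in place of isopropyl on a saturated ring carbon. Among the compounds with values here, no two measured compounds differ in only one place, so no measured step can serve as a guide. With compound 1 at > 500000 nM, the expectation in this assay is a small move towards lower numbers, or none beyond the scatter. The expected change is an at least 1.6-fold lower number from compound 1 to compound 3 (0.22 log units; that floor lies within the scatter). For compound 3, the estimated value is 300000 nM, with an expected range from 80000 nM to 500000 nM.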

Compound 3, half-maximal effective concentration: > 500000 nM
Compound 3 was reported as a limit; the forecaster's own chance of this, stated with the estimate: 65%; middle value at least 1.6-fold (0.22 log units) from the limit.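

In this assay compound 3 gives > 500000 nM, which is a limit of the assay and not a number. Within the data shown here, compound 1 also stands at a limit, so no step from compound 1 to compound 3 can be read: the limit of > 500000 nM in this assay, at which 3 of the 3 values shown sit. Whether cyclohexyl and isopropyl differ at all in this assay, and at what amount any of these compounds would show an effect, stays open.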